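This account rests on a few compounds, and the source may have more. Where it says the series, first, only, none or still open, it means among the compounds named here.

Measured in a functional assay on HeLa cells (Homo sapiens) for antiproliferative activity, read by CCK-8 assay, with a stated time of 72 h, tested at 2 uM; a lower number here means a weaker effect, a higher number a stronger effect of the compound at the concentration tested:
compound 1 `Nc1ccccc1NC(=O)c1ccc(CSC(=S)N2CCN(Cc3ccccn3)CC2)cc1` gives 14.2%;
compound 2 `Nc1ccccc1NC(=O)c1ccc(CSC(=S)N2CCN(c3ccc(Cl)cc3)CC2)cc1` gives 51.2%;
compound 3 `Nc1ccccc1NC(=O)c1ccc(CSC(=S)N2CCc3cc(Cl)ccc32)cc1` gives 40.1%.

Among these three numbers compound 1 stands lowest: compound 3 lies well above it, and the single-change step a number 37 percentage points higher from compound 1 to compound 2 (beyond the scatter) is large. Compound 4 `CN1CCN(C(=S)SCc2ccc(C(=O)Nc3ccccc3N)cc2)CC1` differs from compound 1 by hydrogen in place of pyridin-2-yl on a saturated chain carbon bound to an amine nitrogen in a ring. Within the data shown here, no measured step makes exactly this change. Among the measured compounds shown here, the one step starting from compound 1, a number 37 percentage points higher from compound 1 to compound 2 (beyond the scatter), swaps the whole (pyridin-2-yl)methyl group for 4-chlorophenyl, a different substituent altogether, so it bears on the present change only loosely. With a hydrogen entering in place of pyridin-2-yl and nothing else added, a step within the scatter is expected, a number 0.8 percentage points higher from compound 1 to compound 4 (within the scatter). Compound 4 is therefore estimated at 15%, with a range from 3% to 35%.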

Compound 4, a percentage reported as inhibition, at one concentration (the size of the read-out at that concentration, not a potency): 52.6%
Compound 4: the middle estimate sits 37.6 percentage points below what was measured; measured number above the stated range.
By their numbers in this assay, from the lowest: compound 1; then compound 3; then compounds 2 and 4 (each within the scatter of the next).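

Cutting pyridin-2-yl away to leave methyl is a large change at this position in this assay (a number 38.4 percentage points higher from compound 1 to compound 4 (beyond the scatter)), so the (pyridin-2-yl)methyl group of compound 1 goes with a low number. Methyl and 4-chlorophenyl on this amine nitrogen in a ring cannot be told apart (a number 1.4 percentage points higher from compound 2 to compound 4 (within the scatter)), so an aromatic ring there is not needed, and 4-methylpiperazin-1-yl also exceeds 5-chloro-2,3-dihydro-1H-indol-1-yl on the thiocarbonyl carbon (a number 12.5 percentage points higher from compound 3 to compound 4 (beyond the scatter)). Nothing available explains these steps.

Going by these compounds, whether an ethyl group or a longer chain on this nitrogen would hold the number remains open. So does whether plain benzyl, without the pyridine nitrogen, would pull it down as (pyridin-2-yl)methyl does.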